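The compounds below may be only part of what the source reports. "The series", "measured", "known", "first", "only" and "open" are said of these compounds alone.

In an ADME assay on L02 cells (Homo sapiens) for cytotoxicity, read by MTT assay, with a stated time of 48 h (a higher number here means a weaker inhibitor, a lower number a stronger inhibitor), compound 1 `CCn1c(C(=O)NCCCN(C)C)ccc1C(CC)(CC)c1ccc(OCC(=O)C(C)(C)C)c(C)c1` gives 670 nM, compound 2 `CCOC(=O)CN(C)C(=O)c1ccc(C(CC)(CC)c2ccc(OCC(O)C(C)(C)C)c(C)c2)n1CC` gives 10100 nM, and compound 3 `CCn1c(C(=O)NCC(OC)OC)ccc1C(CC)(CC)c1ccc(OCC(O)C(C)(C)C)c(C)c1` gives 22200 nM, the highest number of the three. Compound 4 `C#CC(C)OC(=O)c1ccc(C(CC)(CC)c2ccc(OCC(O)C(C)(C)C)c(C)c2)n1CC` has not yet been measured. It keeps the rest of compound 3 but carries (1-methylprop-2-yn-1-yl)oxy in place of (2,2-dimethoxyethyl)amino on a carbonyl carbon.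

Among the compounds with values here, only one measured step involves a swap at this carbonyl carbon: a 2.2-fold higher number from compound 2 to compound 3 (0.34 log units; beyond the scatter). That step is modest. Compound 1 differs from compound 3 in more than one place, so it offers no clean comparison. Within the data shown here, no measured compound yet carries the entering group, which leaves the direction uncertain. With compound 3 at the top of the series, a small move towards a lower number seems most likely, no larger than the measured step. The expected change is a 1.6-fold lower number from compound 3 to compound 4 (0.20 log units; within the scatter). For compound 4 the estimated value is 14000 nM, with an expected range from 5000 nM to 40000 nM.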

Compound 4, half-maximal inhibitory concentration: 23700 nM
For compound 4 the middle estimate is 1.7-fold (0.23 log units) below the measured one, and the stated range covers the measured number.
By their numbers in this assay, from the lowest: compound 1; then compound 2; then compounds 3 and 4 (each within the scatter of the next).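

In this assay, putting (1-methylprop-2-yn-1-yl)oxy in place of (2,2-dimethoxyethyl)amino on this carbonyl carbon gives a 1.1-fold higher number from compound 3 to compound 4 (0.03 log units; within the scatter) and so leaves the two compounds indistinguishable. The entering group has no hydrogen-bond donor and brings a triple bond, yet these differences leave no readable trace in this number. Set against ((ethoxycarbonyl)methyl)(methyl)amino, the same entering group gives a 2.3-fold higher number from compound 2 to compound 4 (0.37 log units; beyond the scatter) as a second modest step, so among these three groups only ((ethoxycarbonyl)methyl)(methyl)amino sets its compound apart.

On these data alone, whether a carboxylic acid or a morpholine on this carbonyl carbon would shift the number further remains open. Nothing available explains why these groups give the numbers they do.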